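From thiophen-2-yl to thiophen-3-yl at the limit

The source may report more compounds than this note shows. Statements on the series, on what has been measured and on what is new or still open speak of the compounds shown alone.

Two close relatives have been tested so far in a functional assay on HCT-116 cells (Homo sapiens), read by MTT assay, with a stated time of 72 h; on this read-out lower numbers stand for stronger inhibition and higher numbers for weaker inhibition. Compound 1 (`Cc1ncnc2c1c(-c1ccoc1)cn2[C@@H]1O[C@H](CO)[C@@H](O)[C@H]1O`) gives > 20000 nM, which is a limit of the assay and not a number. Compound 2 (`Cc1ncnc2c1c(-c1cccs1)cn2[C@@H]1O[C@H](CO)[C@@H](O)[C@H]1O`) gives > 20000 nM, which is also only a limit. Compound 2 therefore has no exact value, and the one other result beside it is a limit too. Taken together, the results show (the limit of > 20000 nM in this assay, at which 2 of the 2 values shown sit).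

Compound 3 (`Cc1ncnc2c1c(-c1ccsc1)cn2[C@@H]1O[C@H](CO)[C@@H](O)[C@H]1O`) keeps the shared core and differs from compound 2 in one group: thiophen-3-yl in place of thiophen-2-yl on an aromatic carbon. Among the measured compounds shown here, the only measured step that bears on this change is a step that the two limits leave unreadable from compound 1 to compound 2, also a swap of one ring group for another, and it offers no size to carry over. No step beyond the usual scatter is therefore expected in this assay, and no direction can be named. The estimated change is a number no higher from compound 2 to compound 3 (the limit leaves the size open). Another limit is the likeliest report, and for compound 3 the estimated value is 20000 nM, with an expected range from 6000 nM to 40000 nM.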

Compound 3, half-maximal inhibitory concentration: 1430 nM
The estimate for compound 3 lay 14-fold (1.15 log units) above the measured number, outside the stated range (below it).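

The position turns out to be sensitive to how the ring group is attached. In this assay, where a lower number means stronger inhibition, simply moving the attachment point of the same thiophene ring gives an at least 13-fold lower number from compound 2 to compound 3 (1.14 log units; beyond the scatter), even though the two groups have the same atoms, joined differently. Exchanging furan-3-yl for thiophen-3-yl gives an at least 13-fold lower number from compound 1 to compound 3 (1.14 log units; beyond the scatter), so with this third compound, the ring group at this carbon is seen to make a clear difference, which the first two compounds could not show. Compound 1 and compound 2 remain limits of the assay, so the full size of both steps is unknown and the step between these two compounds cannot be read: the limit of > 20000 nM in this assay, at which 2 of the 3 values shown sit.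

The compounds shown carry only five-membered aromatic rings with one hetero atom at this carbon, so it remains open how a larger ring such as phenyl or pyridyl, or a simple amine, would fare. A furan-2-yl group would be needed to tell whether the attachment point also matters for the furan ring.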